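The source may hold more compounds than are shown below. What is called first, only, known or untested is meant among the compounds shown, and "the series" means these compounds.

Compound 1 `COc1cc(N2C(=O)[C@@H](Oc3ccccc3)[C@H]2c2ccc(Br)cc2)cc(OC)c1OC` gives 48000 nM
Compound 2 `COc1cc(N2C(=O)[C@@H](Oc3ccccc3)[C@H]2c2ccc(C#N)cc2)cc(OC)c1OC` gives 31600 nM
Compound 3 `COc1ccc([C@@H]2[C@H](Oc3ccccc3)C(=O)N2c2cc(OC)c(OC)c(OC)c2)cc1[N+](=O)[O-]` gives 69000 nM

All three values come from a functional assay on MCF7 cells (Homo sapiens) for antiproliferative activity, read by MTT assay, with stated times of 24 h and 72 h (on this read-out lower numbers stand for stronger inhibition and higher numbers for weaker inhibition), and span a narrow band. Compound 3 stands on the high side of the set (a 2.2-fold higher number from compound 2 to compound 3 (0.34 log units; beyond the scatter)), yet level with its other neighbour (a 1.4-fold higher number from compound 1 to compound 3 (0.16 log units; within the scatter)). Compound 4 `COc1cc(N2C(=O)[C@@H](Oc3ccccc3)[C@H]2c2cccc([N+](=O)[O-])c2)cc(OC)c1OC` differs from compound 3 at one place (hydrogen in place of methoxy on an aromatic carbon), with hydrogen in place of methoxy on an aromatic carbon. Among the measured compounds shown here, no measured step removes that methoxy alone. The nearest evidence is the whole-aryl swaps, which stay small, as does a 1.5-fold lower number from compound 1 to compound 2 (0.18 log units; within the scatter) alongside them. In this assay no step beyond the scatter is therefore expected, with a slight lean toward a lower number. The expected change is small (a 1.4-fold lower number from compound 3 to compound 4 (0.14 log units; within the scatter)). For compound 4 the estimated value is 50000 nM (expected range 22000 nM to 110000 nM).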

Compound 4, half-maximal inhibitory concentration: 30000 nM
Compound 4: middle estimate off by 1.7-fold (0.22 log units), on the high side; low and high end bracket the measured number.
By their numbers in this assay, from the lowest: compounds 4, 2, 1 and 3 (each within the scatter of the next, the first and the last beyond it).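

In this assay hydrogen in place of methoxy, ortho to a nitro group, gives a 2.3-fold lower number from compound 3 to compound 4 (0.36 log units; beyond the scatter) as a single-group change on this ring. The 3-nitrophenyl compound then shows a 1.1-fold lower number from compound 2 to compound 4 (0.02 log units; within the scatter) and a 1.6-fold lower number from compound 1 to compound 4 (0.20 log units; within the scatter), so the high number of compound 3 goes with the 4-methoxy-3-nitrophenyl group and not with the nitro group alone. No measurement shown here explains this step.

On these data alone, whether fluoro, hydroxy or an amine at this carbon would read like hydrogen or like methoxy stays open. So does whether the methoxy step holds without the nitro group.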